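Swapping vinyl for chloromethyl on a warhead-bearing carbonyl

This account rests on a few compounds, and the source may have more. Where it says the series, first, only, none or still open, it means among the compounds named here.

Three compounds share a diaryl ether attached to a pyrazole and have been tested in a functional assay on Z-138 cells (Homo sapiens) for inhibition, read by luminescence and CellTiter-Glo, with a stated time of 72 h; on this read-out lower numbers stand for stronger inhibition and higher numbers for weaker inhibition. Compound 1 `O=C(CCl)Nc1ccc(Cn2nc(-c3ccc(Oc4ccccc4)cc3)cc2CO)cc1` gives 400 nM. Compound 3 `C=CC(=O)Nc1ccc(Cn2nc(-c3ccc(Oc4ccccc4)cc3)cc2CO)cc1` gives 6800 nM. Compound 2 `C=CC(=O)N1CCCC(n2nc(-c3ccc(Oc4ccccc4)cc3)cc2C(=O)OCC)C1` gives 44000 nM. Going by the values given here, the one counted change, (chloromethyl in place of vinyl on a carbonyl carbon), made a step of a 17-fold lower number from compound 3 to compound 1 (1.23 log units; beyond the scatter). Compound 4 `CCOC(=O)c1cc(-c2ccc(Oc3ccccc3)cc2)nn1C1CCCN(C(=O)CCl)C1` has not yet been measured; it differs from compound 2 by chloromethyl in place of vinyl on a carbonyl carbon. This is the same kind of change, though here the carbonyl carbon sits on an amide-type nitrogen in a ring rather than on an amide-type nitrogen. The difference between the cores of compound 2 and compound 3 is not broken down here. Because compound 2 gives 44000 nM and the earlier change gave a 17-fold lower number from compound 3 to compound 1 (1.23 log units; beyond the scatter), compound 4 is expected to improve by about an 11-fold lower number from compound 2 to compound 4 (1.04 log units; beyond the scatter), giving an estimated 4000 nM, likely between 800 nM and 25000 nM.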

Compound 4, half-maximal inhibitory concentration: 1300 nM
For compound 4 the middle estimate is 3.1-fold (0.49 log units) above the measured one; the measured number falls inside the stated range.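

In this assay, chloromethyl in place of vinyl on a carbonyl carbon gave a 34-fold lower number from compound 2 to compound 4 (1.53 log units; beyond the scatter) on the second core. The step on this core and the earlier one cannot be told apart in size: the same change on two cores in this assay, a 17-fold lower number (1.23 log units; beyond the scatter) from compound 3 to compound 1 and a 34-fold lower number (1.53 log units; beyond the scatter) from compound 2 to compound 4, 2.0-fold (0.30 log units) apart, within the scatter of two such steps. This shows the change carrying over between these two cores only: two pairs set no rule for other cores, and these numbers alone do not say why the chloromethyl compounds give lower numbers.

Still open, as far as these compounds go, is how other groups on that carbonyl carbon, such as a plain methyl or a longer chain ending in chlorine, would read in this assay. Also open, from the compounds shown here alone, is whether the step holds on a core carrying an amine or a carboxylic acid.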